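A few compounds are considered here, and "the series" means these few. Any claim that something is new, unique, unknown or untested is made for them only; others in the source may bear on it.

Among the compounds with values here, compound 1 `CCN(CC)C/C1=C/C[C@](C)(CCC=C(C)C)/C=C/[C@@H](OC(=O)C=C(C)C)[C@](C)(O)/C=C/C1=O` is the stronger of the two compounds measured so far. In a functional assay on SW480 cells (Homo sapiens) for antiproliferative activity, read by MTT assay, with a stated time of 48 h (a higher number here means a weaker inhibitor, a lower number a stronger inhibitor), compound 1 gives 270 nM, the lowest number recorded, while compound 2 `CC(C)=CCC[C@](C)(/C=C/[C@@H](OC(=O)C=C(C)C)[C@](C)(O)/C=C/C(=O)/C=C/N(C)C)CC=O` gives 10300 nM, a gap well beyond the usual scatter. Compound 3 `CC(C)=CCC[C@]1(C)/C=C/[C@@H](OC(=O)C=C(C)C)[C@](C)(O)/C=C/C(=O)/C(C(=O)N(C(C)C)C(C)C)=C\C1` keeps the core of compound 1 but carries diisopropylcarbamoyl in place of (diethylamino)methyl on a double-bonded ring carbon. Within the data shown here, no measured pair shows a change of this kind, so the outcome is uncertain; a moderate weakening is expected, a 3.3-fold higher number from compound 1 to compound 3 (0.52 log units; beyond the scatter), probably somewhat beyond the scatter. Compound 3 is therefore estimated at 900 nM, with a likely range from 200 nM to 4000 nM.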

Compound 3, half-maximal inhibitory concentration: 16000 nM
Beside the measured number, compound 3's estimate is 18-fold (1.25 log units) below it; measured number outside the range, above it.
By their numbers in this assay, from the lowest: compound 1; then compounds 2 and 3 (each within the scatter of the next).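

Within the data shown here, this is the first measured change on this double-bonded ring carbon. In this assay, diisopropylcarbamoyl in place of (diethylamino)methyl gives a 59-fold higher number from compound 1 to compound 3 (1.77 log units; beyond the scatter), so the group held at this carbon strongly affects the antiproliferative reading. No measurement available here accounts for the size of this loss. On these data alone, because the step changes the whole group at once, it remains open whether the carbonyl or the isopropyl groups matter more. A diethylcarbamoyl group or a (dimethylamino)methyl group at this carbon could help separate those parts.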